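A few compounds are considered here, and "the series" means these few. Any claim that something is new, unique, unknown or untested is made for them only; others in the source may bear on it.

Compound 1 `Cn1c(=O)c2[nH]c(SCC(=O)c3ccccc3)nc2n(C)c1=O` is the simplest member of this small set. In a functional assay on HT-29 cells (Homo sapiens) for inhibition, read by MTT assay, with a stated time of 48 h (on this read-out lower numbers stand for stronger inhibition and higher numbers for weaker inhibition), compound 1 gives 5900 nM. Compound 2 `COc1ccc(C(=O)CSc2nc3c([nH]2)c(=O)n(C)c(=O)n3C)cc1` differs from it by a single change, (methoxy in place of hydrogen on an aromatic carbon), and in this assay compound 2 gives 8100 nM. The resulting step, a 1.4-fold higher number from compound 1 to compound 2 (0.14 log units; within the scatter), is too small to count as a real difference. Compound 3 `Cn1c(=O)c2[nH]c(SC/C(=N/O)c3ccccc3)nc2n(C)c1=O` shares the same core as compound 1 but carries a different group on the side chain; the difference between the two cores is not broken down here. In this assay compound 3 gives 6700 nM, a number that sits within the scatter of both compound 1 and compound 2.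

Compound 4 `COc1ccc(/C(CSc2nc3c([nH]2)c(=O)n(C)c(=O)n3C)=N\O)cc1` has not yet been measured. It differs from compound 3 by methoxy in place of hydrogen on an aromatic carbon, the same change that separates compound 1 from compound 2, made at the same kind of place. Because the earlier step of a 1.4-fold higher number from compound 1 to compound 2 (0.14 log units; within the scatter) stayed within the scatter, compound 4 is expected to give 9000 nM, with a likely range from 5000 nM to 17000 nM. The expected step is therefore a 1.3-fold higher number from compound 3 to compound 4 (0.13 log units; within the scatter).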

Compound 4, half-maximal inhibitory concentration: 1700 nM
Beside the measured number, compound 4's estimate is 5.3-fold (0.72 log units) above it; the measured number lies below the stated range.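

In this assay, methoxy in place of hydrogen on the aromatic ring gives a 3.9-fold lower number from compound 3 to compound 4 (0.60 log units; beyond the scatter), a real gain in inhibition, whereas the same change left no readable difference on the core of compound 1. The two steps therefore do not agree, and in this series the result of the change on one core cannot simply be carried over to the other: the same change on two cores in this assay, a 1.4-fold higher number (0.14 log units; within the scatter) from compound 1 to compound 2 and a 3.9-fold lower number (0.60 log units; beyond the scatter) from compound 3 to compound 4, 5.4-fold (0.73 log units) apart, beyond the scatter of two such steps. Among the compounds shown here, this comparison rests on only two pairs of compounds, so it shows that the outcome of adding methoxy differs between these two cores, but it does not show why it differs or how the change would behave on any further core.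

The compounds shown carry only hydrogen or methoxy on this ring, so it remains open whether a chlorine, a hydroxyl or an ethoxy group would follow the same split between the two cores. From the compounds shown here alone, it also remains open whether an amine or a carboxylic acid at that place would do so.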